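Methyl to methoxy on the fused ring: expected step

The compounds below may be only part of what the source reports. "The series", "measured", "known", "first", "only" and "open" are said of these compounds alone.

Measured compounds:
compound 1 `COc1ccc2nc(NC(=O)CNC(=O)c3nn(-c4ccccc4OC)c(=O)c4ccccc34)sc2c1` gives 90 nM
compound 2 `Cc1ccc2nc(NC(=O)CNC(=O)c3nn(-c4ccc(F)cc4)c(=O)c4ccccc34)sc2c1` gives 100 nM

In an assay on L cells for inhibition of Protein-serine O-palmitoleoyltransferase porcupine (Mus musculus), read by reporter gene assay, with a stated time of 24 h (on this read-out lower numbers stand for an effect already at smaller amounts and higher numbers for an effect only at larger amounts of compound), compound 1 gives 90 nM and compound 2 gives 100 nM; the two numbers sit within the scatter of each other, so no order between them is claimed. Compound 3 `COc1ccc2nc(NC(=O)CNC(=O)c3nn(-c4ccc(F)cc4)c(=O)c4ccccc34)sc2c1` is not yet measured. It differs from compound 2 by methoxy in place of methyl on an aromatic carbon. Among the measured compounds shown here, no measured pair differs in one place only, so the size of this step is not known from a direct comparison. Compound 1 carries the same methoxy group on the same ring and gives 90 nM. On that basis no step beyond the scatter is expected in this assay, in either direction. The expected step is a 1.3-fold lower number from compound 2 to compound 3 (0.10 log units; within the scatter). Compound 3 is estimated at 80 nM, with a range from 40 nM to 160 nM.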

Compound 3, half-maximal effective concentration: 90 nM
Compound 3: the middle estimate sits 1.1-fold (0.05 log units) below what was measured; the range from low to high includes it.
By their numbers in this assay, from the lowest: compounds 1, 3 and 2 (each within the scatter of the next).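

In this assay, the change from 6-methyl-1,3-benzothiazol-2-yl to 6-methoxy-1,3-benzothiazol-2-yl can now be read directly with the 4-fluorophenyl group held constant, and the step lies within the scatter (a 1.1-fold lower number from compound 2 to compound 3 (0.05 log units; within the scatter)). The new compound also gives a direct reading on the aromatic nitrogen with the 6-methoxy group held constant: 4-fluorophenyl in place of 2-methoxyphenyl leaves the number unmoved (no change at the digits printed from compound 1 to compound 3 (within the scatter)). Neither single change therefore shifts this read-out beyond the scatter, and no available measurement accounts for that.

With only methyl and methoxy shown at the 6-position, it remains open whether an amine, a carboxylic acid or a longer chain such as butoxy would move the number beyond the scatter. The same question stands on the aromatic nitrogen, where a pyridyl or benzyl group remains unplaced.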